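This account rests on a few compounds, and the source may have more. Where it says the series, first, only, none or still open, it means among the compounds named here.

Of the compounds shown here, three sharing one core have been read in a toxicity assay on Vero C1008 cells (Chlorocebus sabaeus) for cytotoxicity, read by MTT assay, with a stated time of 48 h; on this read-out lower numbers stand for higher toxicity in this test and higher numbers for lower toxicity in this test. Compound 1 (`O=C(Nc1cccc([N+](=O)[O-])c1)c1cc(Cl)ccc1O`) gives 3530 nM, compound 2 (`O=C(Nc1ccc(F)c(Cl)c1)c1cc(Cl)ccc1O`) gives 2440 nM, and compound 3 (`O=C(Nc1ccc(F)cc1)c1cc(Cl)ccc1O`) gives 6780 nM. Compound 3 therefore lies within the scatter of compound 1 and beyond it from compound 2, on the side of lower toxicity in this test. Compound 4 (`O=C(Nc1ccc(O)cc1)c1cc(Cl)ccc1O`) has hydroxy in place of fluoro on an aromatic carbon, para to a large group: hydroxy in place of fluoro on an aromatic carbon. For the measured compounds named here, only one measured step offers a guide, and it is a different exchange: a 2.8-fold higher number from compound 2 to compound 3 (0.44 log units; beyond the scatter), which is modest. Going by the values given here, no measured step shows this swap, so no step beyond the scatter is expected. The expected change is a 1.2-fold lower number from compound 3 to compound 4 (0.09 log units; within the scatter). The estimate for compound 4 is 5500 nM, with a range of 2200 nM to 14000 nM.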

Compound 4, half-maximal cytotoxic concentration: > 100000 nM
Compound 4: a limit, no number (the forecaster's own chance of this, stated with the estimate: 5%); at least 18-fold (1.25 log units) between middle value and limit.
By their numbers in this assay, from the lowest: compounds 2, 1 and 3 (each within the scatter of the next, the first and the last beyond it). At a limit, above all of these: compound 4.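

In this assay, hydroxy in place of fluoro on an aromatic carbon, para to a large group, gives an at least 14-fold higher number from compound 3 to compound 4 (1.16 log units; beyond the scatter), on the side of lower toxicity in this test. For the compounds shown here, the only earlier step, a 2.8-fold higher number from compound 2 to compound 3 (0.44 log units; beyond the scatter), is a different exchange and modest, whereas this one is large, so a change of one heavy atom at this position can move the read-out strongly. Compound 4 gives > 100000 nM, which is a limit of the assay and not a number: the limit of > 100000 nM in this assay, at which 1 of the 4 values shown sits. The compounds shown do not tell how far beyond its limit compound 4 lies. Nor do they tell whether an amine or a methoxy group at this position would read like hydroxy or like fluoro.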